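Aryl exchange on the ring nitrogen: compound 3 to compound 4

The source may report more compounds than this note shows. Statements on the series, on what has been measured and on what is new or still open speak of the compounds shown alone.

Measured compounds:
Compound 1 `Cc1ccc(C)c(-n2nncc2CN2C(=O)C3(C(C#N)=C(N)Oc4c3c3nc5ccccc5nc3c3ccccc43)c3ccccc32)c1` — in a functional assay on MCF7 cells (Homo sapiens) for antiproliferative activity, read by MTT assay, with a stated time of 48 h (on this read-out lower numbers stand for stronger inhibition and higher numbers for weaker inhibition), compound 1 reaches only the assay limit, > 50000 nM.
Compound 2 `Cc1ccc(Cl)cc1-n1nncc1CN1C(=O)C2(C(C#N)=C(N)Oc3c2c2nc4ccccc4nc2c2ccccc32)c2ccccc21` — in this assay compound 2 likewise stops at the limit, > 50000 nM.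
Compound 3 `Cc1cccc(-n2nncc2CN2C(=O)C3(C(C#N)=C(N)Oc4c(N)cc5nc6ccccc6nc5c43)c3ccccc32)c1` — in this assay compound 3 also gives only the limit, > 50000 nM.

Going by the values given here, compound 3 therefore stands at the ceiling of what has been measured; no number separates it from the other two, since the limit of > 50000 nM in this assay, at which 3 of the 3 values shown sit, describes where every value so far sits. Among the compounds with values here, the one step that can be drawn, a step that the two limits leave unreadable from compound 1 to compound 2, swaps one aryl substituent for another on the same ring and stays unreadable because both ends rest at the limit.

Compound 4 `N#CC1=C(N)Oc2c(N)cc3nc4ccccc4nc3c2C12C(=O)N(Cc1cnnn1-c1ccc(Cl)cc1Cl)c1ccccc12` departs from compound 3 by 2,4-dichlorophenyl in place of 3-methylphenyl on an aromatic nitrogen. Within the data shown here, this is again an exchange of substituents on the aryl group carried by the ring nitrogen, the same class of change as the unreadable step already seen, so no measured step gives its size or direction. Compound 4 is accordingly expected to remain at the limit, with the estimated step that the limit leaves unreadable from compound 3 to compound 4 read as no change beyond the scatter. The estimate for compound 4 in this assay is 60000 nM, within 20000 nM to 200000 nM.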

Compound 4, half-maximal inhibitory concentration: > 50000 nM
Compound 4 ended at the assay's limit; the forecaster's own chance of this, stated with the estimate: 80%; the middle value does not contradict the limit.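

No step can be read from compound 3 to compound 4 in this assay because both results are limits of the assay and not numbers: the limit of > 50000 nM in this assay, at which 4 of the 4 values shown sit.

The compounds shown leave open whether any aryl exchange on the ring nitrogen, or any change to the shared core, gives a measurable antiproliferative value.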